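Swapping the benzyl substituent on a shared amide core

The source may report more compounds than this note shows. Statements on the series, on what has been measured and on what is new or still open speak of the compounds shown alone.

Measured so far:
compound 1, `CC(C)c1c(C(=O)NCc2ccccc2)nc(-c2ccc(F)cc2)n1CC[C@@H](O)C[C@@H](O)CC(=O)O`: 0.3 nM
compound 2, `COc1cccc(CNC(=O)c2nc(-c3ccc(F)cc3)n(CC[C@@H](O)C[C@@H](O)CC(=O)O)c2C2CC2)c1`: 0.2 nM

Both compounds were tested in a functional assay on cells (Hepatocyte, Rattus norvegicus) for inhibition, read by scintillation counting, with a stated time of 4 h; a higher number here means a weaker inhibitor, a lower number a stronger inhibitor. Compound 2 gives the lower of the two numbers, yet its gap to compound 1 lies within the usual scatter of repeated measurements, so the two cannot be told apart on these data alone. Compound 3, `O=C(O)C[C@H](O)C[C@H](O)CCn1c(-c2ccc(F)cc2)nc(C(=O)NCc2ccc(F)cc2)c1C1CC1`, has not yet been measured. It differs from compound 2 in one place: 4-fluorophenyl in place of 3-methoxyphenyl on a saturated chain carbon bound to an amide-type nitrogen. Compound 1 carries an unsubstituted benzyl group at the same position, and compound 1 and compound 2 sit within the scatter of each other, which suggests that a small change on this ring does little here. No step beyond the scatter is therefore expected for compound 3, with a 1.5-fold higher number from compound 2 to compound 3 (0.18 log units; within the scatter) lying in either direction. Compound 3 is estimated at 0.3 nM, with a range from 0.1 nM to 0.9 nM.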

Compound 3, half-maximal inhibitory concentration: 0.7 nM
Compound 3: the middle estimate sits 2.3-fold (0.37 log units) below what was measured; the measured number falls inside the stated range.
By their numbers in this assay, from the lowest: compounds 2 and 1 (each within the scatter of the next); then compound 3.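

For the compounds shown here, the ring on this amide is not a silent spot: in this assay the swap gives a 3.5-fold higher number from compound 2 to compound 3 (0.54 log units; beyond the scatter), a modest step, but one that lies beyond the scatter, and no earlier pair differing in one place could show this. The loss is limited, since compound 3 still reads 0.7 nM and so remains a strong inhibitor. Nothing measured here accounts for the step.

The swap replaces the methoxy group with fluorine and also moves the substituent from the 3 to the 4 position of the ring, so these two changes cannot be separated on the compounds shown. Comparing 3-fluorophenyl and 4-methoxyphenyl would separate them, while an amine on this ring would test a different kind of group.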